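From compound 3 to compound 4: bromo replaced by methyl

The source may hold more compounds than are shown below. What is called first, only, known or untested is meant among the compounds shown, and "the series" means these compounds.

Compound 3 `Cn1cc(/C=C/C(=O)c2cccc(Br)c2)cc1/C=C/C(=O)NO` gives 480 nM in an assay on isolated protein for inhibition of histone deacetylase HD1B (Zea mays) (on this read-out higher numbers stand for weaker inhibition and lower numbers for stronger inhibition), the lowest number of the three measured; compound 2 `Cn1cc(/C=C/C(=O)c2ccc(F)cc2)cc1/C=C/C(=O)NO` gives 24900 nM and compound 1 `Cn1cc(/C=C/C(=O)c2cccc(Cl)c2)cc1/C=C/C(=O)NO` gives 31400 nM. The two steps leading to compound 3 are large, a 65-fold lower number from compound 1 to compound 3 (1.82 log units; beyond the scatter) and a 52-fold lower number from compound 2 to compound 3 (1.71 log units; beyond the scatter), whereas a 1.3-fold lower number from compound 1 to compound 2 (0.10 log units; within the scatter) is not. Compound 4 `Cc1cccc(C(=O)/C=C/c2cc(/C=C/C(=O)NO)n(C)c2)c1` differs from compound 3 by methyl in place of bromo on an aromatic carbon. Only a 65-fold lower number from compound 1 to compound 3 (1.82 log units; beyond the scatter) concerns the same aromatic carbon, and it shows that a single-atom exchange there can move the number far. Within the data shown here, no measured step tells where methyl falls, so compound 4 is expected to sit between the extremes, a step of a 10-fold higher number from compound 3 to compound 4 (1.02 log units; beyond the scatter). The estimate for compound 4 is 5000 nM, range 800 nM to 30000 nM.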

Compound 4, half-maximal inhibitory concentration: 2500 nM
The estimate for compound 4 lay 2.0-fold (0.30 log units) above the measured number, and the stated range covers the measured number.
By their numbers in this assay, from the lowest: compound 3; then compound 4; then compounds 2 and 1 (each within the scatter of the next).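

Among these compounds, at this aromatic carbon, bromo is not the only group that gives a low number: methyl falls short of it, with a 5.2-fold higher number from compound 3 to compound 4 (0.72 log units; beyond the scatter), but still improves on chloro, with a 13-fold lower number from compound 1 to compound 4 (1.10 log units; beyond the scatter). Compound 4 also stands clear of the 4-fluorophenyl compound, with a 10-fold lower number from compound 2 to compound 4 (1.00 log units; beyond the scatter). Nothing measured here accounts for the order bromo, methyl, chloro at this carbon.

Open, from the compounds shown here alone, is where an ethyl, a methoxy or an amine at the same carbon would fall relative to methyl and bromo. Also open, going by these compounds, is whether a carboxylic acid there would be tolerated at all.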